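Pyridinylmethyl isomers on the ring nitrogen: cytotoxicity working notes

The source may hold more compounds than are shown below. What is called first, only, known or untested is meant among the compounds shown, and "the series" means these compounds.

Measured compounds:
Compound 1, `CS(=O)(=O)Nc1ccc2c(c1)S(=O)(=O)C=C(c1c(O)c3cc(F)ccc3n(Cc3ccc(F)c(F)c3)c1=O)N2`: > 50000 nM
Compound 2, `CS(=O)(=O)Nc1ccc2c(c1)S(=O)(=O)C=C(c1c(O)c3cc(F)ccc3n(Cc3ccccn3)c1=O)N2`: > 50000 nM

In an ADME assay on 2209-23 cells (Homo sapiens) for cytotoxicity, read by WST assay (on this read-out higher numbers stand for lower toxicity in this test and lower numbers for higher toxicity in this test), compound 1 reaches only the upper limit of the test, > 50000 nM. In this assay compound 2 likewise reaches only that limit, > 50000 nM. Going by the values given here, the one measured step, a step that the two limits leave unreadable from compound 1 to compound 2, cannot be sized because both values sit at the limit (the limit of > 50000 nM in this assay, at which 2 of the 2 values shown sit). Compound 2 thus stands at the limit, with no numeric value behind it.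

Compound 3, `CS(=O)(=O)Nc1ccc2c(c1)S(=O)(=O)C=C(c1c(O)c3cc(F)ccc3n(Cc3cccnc3)c1=O)N2`, is the next isomer: pyridin-3-yl in place of pyridin-2-yl on a saturated chain carbon bound to an aromatic nitrogen. Among the compounds with values here, the only measured step is unreadable, so nothing numeric carries over to this change; the two measured compounds agree only in both lying at the limit. Compound 3 is expected to stay at that limit as well, estimated at 70000 nM (range 30000 nM to 200000 nM). The expected step, a step that the limit leaves unreadable from compound 2 to compound 3, is thus none beyond the scatter.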

Compound 3, half-maximal cytotoxic concentration: > 50000 nM
Compound 3: only a limit was reported; the forecaster's own chance of this, stated with the estimate: 85%; the middle value is on the limit's open side.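

Compound 3 gives only a limit in this assay, as do compound 1 and compound 2, so neither new step to compound 3 can be read: the limit of > 50000 nM in this assay, at which 3 of the 3 values shown sit.

From the compounds shown here alone, whether 3,4-difluorophenyl, pyridin-2-yl and pyridin-3-yl differ at all in this assay remains open.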